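This account rests on a few compounds, and the source may have more. Where it says the series, first, only, none or still open, it means among the compounds named here.

Values so far in a functional assay on MCF7 cells (Homo sapiens) for inhibition, read by CCK-8 assay, with a stated time of 48 h; a higher number here means a weaker inhibitor of growth, a lower number a stronger inhibitor of growth
- compound 1 `Cc1ccccc1Nc1nc(NC2CC2)ncc1Cl` gives > 100000 nM, which is a limit of the assay
- compound 2 `Cc1ccccc1Nc1nc(Nc2ccccn2)ncc1Cl` gives 31400 nM
- compound 3 `COc1ccc(CNc2nc(Nc3ccc(N4CCN(C)CC4)cn3)ncc2Cl)cc1` gives 17300 nM

Going by the values given here, compound 3 and compound 2 lie within the scatter of each other, and these are the only two true numbers. The next change leads to compound 4 `CC(C)c1cccc(Nc2nc(Nc3ccc(N4CCN(C)CC4)cn3)ncc2Cl)c1` and reads (3-isopropylphenyl in place of 4-methoxybenzyl on a nitrogen on an aromatic ring), that is, 3-isopropylphenyl in place of 4-methoxybenzyl on a nitrogen on an aromatic ring.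

Among the compounds with values here, only one measured step exists, an at least 3.1-fold lower number from compound 1 to compound 2 (0.50 log units; beyond the scatter), and it exchanges a different group, so it bears on this change only loosely. Within the data shown here, no measured step exchanges the 4-methoxybenzyl group alone. As in compound 4, an aromatic ring sits directly on this nitrogen in compound 2, which gives 31400 nM in this assay, so no loss of growth inhibition is expected from that arrangement. A modest move to a lower number is expected, though a result within the scatter would not surprise. The expected size is a 1.9-fold lower number from compound 3 to compound 4 (0.28 log units; within the scatter), an estimate resting on very few data. For compound 4 the estimated value is 9000 nM, with an expected range from 1800 nM to 40000 nM.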

Compound 4, concentration for 50% growth inhibition: 8640 nM
For compound 4 the middle estimate is 1.0-fold (0.02 log units) above the measured one; the measured number falls inside the stated range.
By their numbers in this assay, from the lowest: compounds 4, 3 and 2 (each within the scatter of the next, the first and the last beyond it). At a limit, above all of these: compound 1.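

In this assay the exchange of 4-methoxybenzyl for 3-isopropylphenyl on this nitrogen gives a 2.0-fold lower number from compound 3 to compound 4 (0.30 log units; within the scatter), so the two compounds cannot be told apart and this position accepts the change without a measurable loss of growth inhibition. Both groups hold 9 heavy atoms and one six-membered aromatic ring of carbon only, so the oxygen of 4-methoxybenzyl, with its hydrogen-bond acceptor, can leave this position while the read-out stays within the scatter. No measurement shown accounts for the size of this step.

Going by these compounds, whether the isopropyl group contributes anything, or whether any group of this size on this nitrogen would serve equally, stays open; an unsubstituted phenyl, or a phenyl carrying a carboxylic acid or an amine, would test this at the same position. Compound 1 remains at > 100000 nM, a limit of the assay and not a number, so the full size of any step that starts from it cannot be read.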